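Cytotoxicity notes on a benzyl-substituted sulfonyl series

The source may report more compounds than this note shows. Statements on the series, on what has been measured and on what is new or still open speak of the compounds shown alone.

Measured so far:
compound 1, `O=C1c2ccccc2N(Cc2ccc(Cl)c(Cl)c2)S(=O)(=O)N1Cc1ccccc1`: 200000 nM
compound 2, `O=C1c2ccccc2N(Cc2ccccc2)S(=O)(=O)N1Cc1ccccc1Cl`: 200000 nM

Both measured compounds were tested in a functional assay on HEL cells (Homo sapiens); on this read-out higher numbers stand for lower toxicity in this test and lower numbers for higher toxicity in this test. Compound 1 gives 200000 nM, and compound 2 gives 200000 nM. At the digits shown, compound 1 stands level with compound 2; the two values lie within the scatter of each other, so nothing can be said about order between them. The shared core is thus tolerated at the same minimum cytotoxic concentration whether the chloro groups sit on one benzyl arm or the other.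

Compound 3, `O=C1c2ccccc2N(Cc2cccc(Cl)c2)S(=O)(=O)N1Cc1ccccc1`, is not yet measured in this assay. Its difference from compound 1 is hydrogen in place of chloro on an aromatic carbon, that is, 3,4-dichlorobenzyl becomes 3-chlorobenzyl. For the measured compounds named here, no measured pair shows what a single chloro removal does here, so the expectation rests only on compound 1 and compound 2 sitting at the same level. The step of no change at the digits printed from compound 1 to compound 3 (within the scatter) is estimated to be none beyond the scatter, in either direction. Compound 3 is therefore expected to give 200000 nM, with a range from 100000 nM to 400000 nM in this assay.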

Compound 3, minimum cytotoxic concentration: > 5000 nM
Compound 3 ended at the assay's limit; the forecaster's own chance of this, stated with the estimate: 30%; the middle value lies beyond the limit too.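

In this assay compound 3 gives > 5000 nM as a limit of the assay and not a number. For the compounds shown here, no step from compound 1 to compound 3 can be read because of this limit: the limit of > 5000 nM in this assay, at which 1 of the 3 values shown sits. Left open is whether 3-chlorobenzyl in place of 3,4-dichlorobenzyl changes the minimum cytotoxic concentration at all.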